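Carboxamide in Place of Imidazole on the Anilide Ring

A few compounds are considered here, and "the series" means these few. Any claim that something is new, unique, unknown or untested is made for them only; others in the source may bear on it.

Compound 3 `O=C(Nc1cccc(-c2ncc[nH]2)c1)N1CCC(Oc2ccccc2Cl)CC1` holds the lowest of the two numbers in an assay on isolated protein for inhibition of acyl-CoA desaturase 1 (Mus musculus) (a higher number here means a weaker inhibitor, a lower number a stronger inhibitor), at 10 nM; compound 2 `O=C(Nc1ccccc1)N1CCC(Oc2ccccc2Cl)CC1` is the nearest at 590 nM. Compound 1 `CNC(=O)c1cccc(NC(=O)N2CCC(Oc3ccccc3Cl)CC2)c1` gives < 4 nM in this assay, which is a limit of the assay rather than a number (the limit of < 4 nM in this assay, at which 1 of the 3 values shown sits).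

Two measured steps shape the picture. Adding 1H-imidazol-2-yl to the bare ring gave a 59-fold lower number from compound 2 to compound 3 (1.77 log units; beyond the scatter), while removing methylcarbamoyl gave an at least 140-fold higher number from compound 1 to compound 2 (2.16 log units; beyond the scatter). Replacing methylcarbamoyl with 1H-imidazol-2-yl gave an at least 2.5-fold higher number from compound 1 to compound 3 (0.39 log units; beyond the scatter).

Compound 4 `NC(=O)c1cccc(NC(=O)N2CCC(Oc3ccccc3Cl)CC2)c1` differs from compound 3 by carbamoyl in place of 1H-imidazol-2-yl on an aromatic carbon. Carbamoyl resembles the methylcarbamoyl of compound 1 more than it does the imidazole of compound 3, and the step of an at least 2.5-fold higher number from compound 1 to compound 3 (0.39 log units; beyond the scatter) ran the other way when methylcarbamoyl was traded for imidazole, so the reverse-direction change here is expected to lower the number in this assay by a modest amount, with a fair chance that only a limit is recorded.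

The step from compound 3 to compound 4 is therefore estimated at a 2.0-fold lower number from compound 3 to compound 4 (0.30 log units; within the scatter). Compound 4 is expected to give 5 nM in this assay, within a range of 2 nM to 15 nM.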

Compound 4, half-maximal inhibitory concentration: 10 nM
Compound 4: the middle estimate sits 2.0-fold (0.30 log units) below what was measured; low and high end bracket the measured number.
By their numbers in this assay, from the lowest: compounds 3 and 4 (each within the scatter of the next); then compound 2. At a limit, below all of these: compound 1.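

At this place, on an aromatic carbon of a six-membered aromatic ring of carbon only, meta to a large group, a carbamoyl with no ring served as well in this assay as the five-membered aromatic 1H-imidazol-2-yl, with no change at the digits printed from compound 3 to compound 4 (within the scatter), and carbamoyl in place of hydrogen gave a 59-fold lower number from compound 2 to compound 4 (1.77 log units; beyond the scatter), so an aromatic ring at this place is not needed for a large step from the bare ring. Hydrogen in place of methyl on the amide-type nitrogen gave an at least 2.5-fold higher number from compound 1 to compound 4 (0.39 log units; beyond the scatter), so this small edit moved the number beyond the scatter, whereas exchanging the imidazole for the carbamoyl did not. The value of compound 1 is a limit and not a number: the limit of < 4 nM in this assay, at which 1 of the 4 values shown sits.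

As far as these compounds go, how a nitrile, a carboxylic acid or an amine at this same place would read in this assay remains open, as does the effect of a longer chain, such as ethyl, on the amide-type nitrogen. All the compounds shown share one core, so whether these steps would hold on a different core also remains unknown.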